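Cyclobutyl for vinyl on the amide nitrogen substituent

This account rests on a few compounds, and the source may have more. Where it says the series, first, only, none or still open, it means among the compounds named here.

Measured compounds:
compound 1, `CCN(Cc1cccc(OC)c1)C(=O)C1CCN(S(=O)(=O)c2ccc3cn[nH]c3c2)CC1`, 85%
compound 2, `CCN(Cc1ccccc1OC)C(=O)C1CCN(S(=O)(=O)c2ccc3cn[nH]c3c2)CC1`, 92%
compound 3, `C=CCN(Cc1ccccc1C(F)(F)F)C(=O)C1CCN(S(=O)(=O)c2ccc3[nH]ncc3c2)CC1`, 79%

In a functional assay on CHO cells for positive allosteric modulation of muscarinic acetylcholine receptor M5 (Homo sapiens), read by calcium flux (on this read-out higher numbers stand for larger maximal responses and lower numbers for smaller maximal responses), compound 3 gives 79%, the lowest of the three numbers shown. Against compound 1 the gap is within the scatter; against compound 2 it lies beyond the scatter, so compound 3 sits clearly under compound 2 but not clearly under compound 1.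

Compound 4, `O=C(C1CCN(S(=O)(=O)c2ccc3[nH]ncc3c2)CC1)N(Cc1ccccc1C(F)(F)F)CC1CCC1`, differs from compound 3 by cyclobutyl in place of vinyl on a saturated chain carbon bound to an amide-type nitrogen; cut one bond further out, the change reads allyl to cyclobutylmethyl. Among the compounds with values here, no measured step touches this part of the molecule. Within the data shown here, the only measured step, a number 7 percentage points higher from compound 1 to compound 2 (within the scatter), concerns the methoxyphenyl and stayed within the scatter, so it offers no guide to the size or direction of a change on the chain carbon bound to the amide-type nitrogen.

With nothing to point either way, compound 4 is expected to stay near compound 3, giving a number 1 percentage points higher from compound 3 to compound 4 (within the scatter), a step not beyond the scatter. The estimate for compound 4 is 80%, with a range from 65% to 95%.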

Compound 4, largest response reached (reported as percent of maximum), in percent of the reference or control that the assay uses: 103%
Compound 4: middle estimate off by 23 percentage points, on the low side, and the stated range ends below it.
By their numbers in this assay, from the lowest: compounds 3, 1 and 2 (each within the scatter of the next, the first and the last beyond it); then compound 4.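

In this assay, within the data shown here, the chain carbon bound to an amide-type nitrogen proves to be a place where a single change can move the read-out: cyclobutyl in place of vinyl gives a number 24 percentage points higher from compound 3 to compound 4 (beyond the scatter), whereas the one earlier step, on the methoxyphenyl, stayed within the scatter. The change removes a double bond outside aromatic rings and adds a four-membered non-aromatic ring of carbon only, while neither group brings hydrogen-bond donors or acceptors. No measurement at hand accounts for the rise.

With the ring, the added carbons and the lost double bond all changing in one step, the compounds shown leave open which of these matters; a saturated propyl, a cyclopropylmethyl or a cyclopentylmethyl group would help separate them. They also leave open whether cyclobutyl acts the same way alongside a methoxyphenyl group.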